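Chain shortening on the second-drawn stereoisomer of the series

The compounds below may be only part of what the source reports. "The series", "measured", "known", "first", "only" and "open" are said of these compounds alone.

Compound 2 `CCCCCCCCNC[C@@H]1OC[C@H](N)[C@@H]1O` in a functional assay on A549 cells (Homo sapiens) for antiproliferative activity, read by MTT assay, with a stated time of 72 h (a lower number here means a stronger inhibitor, a higher number a weaker inhibitor), gives only a limit of the measurement, > 128000 nM. Compound 1 `CCCCCCCNC[C@@H]1OC[C@H](N)[C@H]1O` also gives only a limit, > 128000 nM. Among the measured compounds shown here, compound 3 `CCCCCCCCNC[C@@H]1OC[C@H](N)[C@H]1O` is the one member with a number, giving 71800 nM in this assay. The two measured steps are an at least 1.7-fold lower number from compound 1 to compound 3 (0.25 log units; that floor lies within the scatter) and an at least 1.7-fold lower number from compound 2 to compound 3 (0.25 log units; that floor lies within the scatter); each is only a floor, and both floors lie within the scatter, so neither step shows a change that can be trusted. Compound 4 `CCCCCCCNC[C@@H]1OC[C@H](N)[C@@H]1O` differs from compound 2 by hydrogen in place of methyl on a saturated chain carbon, seven bonds along the chain from an amine nitrogen. This is the mirror of the step from compound 1 to compound 3, applied on the configuration of compound 2. Since an at least 1.7-fold lower number from compound 1 to compound 3 (0.25 log units; that floor lies within the scatter) gave at most a small drop on adding the methyl, removing it from compound 2, which already sits at the limit, is expected to leave compound 4 at the limit as well, a step that the limit leaves unreadable from compound 2 to compound 4. Compound 4 is estimated at 200000 nM, within 100000 nM to 500000 nM.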

Compound 4, half-maximal inhibitory concentration: > 128000 nM
Compound 4 ended at the assay's limit (the forecaster's own chance of this, stated with the estimate: 85%); the middle value does not contradict the limit.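

Compound 4 gives > 128000 nM in this assay, which is a limit, and compound 1 and compound 2 also stand at limits, so neither new step can be read. Left open is how far compound 1, compound 2 and compound 4 actually lie from one another.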